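This account rests on a few compounds, and the source may have more. Where it says the series, first, only, none or still open, it means among the compounds named here.

Working notes on a small series of benzimidazole-free description: four compounds sharing a core, read in a functional assay on HeLa cells (Homo sapiens) for antiproliferative activity, read by MTT assay, with a stated time of 48 h; on this read-out higher numbers stand for weaker inhibition and lower numbers for stronger inhibition.

Compound 2, `FC(F)(F)c1ccc2[nH]c(-c3cn(-c4ccccc4)nc3-c3ccccc3)nc2c1`, gives 1920 nM in this assay. Compound 1, `Cc1ccc2[nH]c(-c3cn(-c4ccccc4)nc3-c3ccccc3)nc2c1`, differs from compound 2 by methyl in place of trifluoromethyl on an aromatic carbon. In this assay compound 1 gives 6560 nM. The step is a 3.4-fold higher number from compound 2 to compound 1 (0.53 log units; beyond the scatter).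

Compound 3, `FC(F)(F)c1ccc2[nH]c(-c3cn(-c4ccccc4)nc3-c3ccc(Cl)cc3)nc2c1`, differs from compound 2 by chloro in place of hydrogen on an aromatic carbon. In this assay compound 3 gives 4420 nM, and the step is a 2.3-fold higher number from compound 2 to compound 3 (0.36 log units; beyond the scatter). The values of compound 1 and compound 3 lie within the usual scatter of each other.

Compound 4, `Cc1ccc2[nH]c(-c3cn(-c4ccccc4)nc3-c3ccc(Cl)cc3)nc2c1`, is not yet measured. It differs from compound 3 by methyl in place of trifluoromethyl on an aromatic carbon. This is the same change as the one from compound 2 to compound 1: the place lines of the two changes are identical word for word, on the shared bicyclic part, and only the core into which the change is made differs, as given above for compound 3 against compound 2. That change occurs twice among these compounds, once measured.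

Expectation: from compound 3 to compound 4 a step of about a 2.9-fold higher number from compound 3 to compound 4 (0.47 log units; beyond the scatter) is estimated in this assay, resting on the single measured instance of this change, a 3.4-fold higher number from compound 2 to compound 1 (0.53 log units; beyond the scatter). Whether the presence of the chloro group alters the size of that step cannot be judged from one pair, so the range is kept wide. Compound 4 is therefore expected to give roughly 13000 nM in this assay, with an estimated span from 6000 nM to 30000 nM.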

Compound 4, half-maximal inhibitory concentration: 5360 nM
Compound 4: the middle estimate sits 2.4-fold (0.38 log units) above what was measured, outside the stated range (below it).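

In this assay, methyl in place of trifluoromethyl gives a 1.2-fold higher number from compound 3 to compound 4 (0.08 log units; within the scatter) on the core carrying chloro, so the change does not carry over at the size it had on the core without chloro: the same change on two cores in this assay, a 3.4-fold higher number (0.53 log units; beyond the scatter) from compound 2 to compound 1 and a 1.2-fold higher number (0.08 log units; within the scatter) from compound 3 to compound 4, 2.8-fold (0.45 log units) apart, beyond the scatter of two such steps

Read along the other edge of the same four compounds, chloro in place of hydrogen gives a 1.2-fold lower number from compound 1 to compound 4 (0.09 log units; within the scatter), and this change does not keep its earlier size either: the same change on two cores in this assay, a 2.3-fold higher number (0.36 log units; beyond the scatter) from compound 2 to compound 3 and a 1.2-fold lower number (0.09 log units; within the scatter) from compound 1 to compound 4, 2.8-fold (0.45 log units) apart, beyond the scatter of two such steps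

The two changes therefore do not add up in this set, and a step measured on one of these cores was a poor guide to the same step on the other, but a single square of four compounds gives no general rule for the series and does not show why the steps differ.

As far as these compounds go, it remains open whether the same lack of additivity appears when the trifluoromethyl or methyl is replaced by another group, such as a nitrile, an amine or a carboxylic acid, or when the chloro is replaced by fluoro, bromo or methoxy. Also open, from the compounds shown here alone, is whether a step on the shared core would keep its size with a longer chain in place of methyl.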